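This account rests on a few compounds, and the source may have more. Where it says the series, first, only, none or still open, it means among the compounds named here.

Among the measured compounds shown here, in a functional assay on MCF7 cells (Homo sapiens) for cytotoxicity, read by MTT assay, with a stated time of 72 h (on this read-out lower numbers stand for stronger inhibition and higher numbers for weaker inhibition), compound 1 `CCC[S+]([O-])CCCCN=C=S` gives 5960 nM and compound 2 `CC(C)[S+]([O-])CCCCN=C=S` gives 8820 nM, so compound 2 stands within the scatter of the only other measured value. Compound 3 `CC(C)[S+]([O-])CCCCCN=C=S` differs from compound 2 by a group of 4 heavy atoms (2 carbon, 1 nitrogen, 1 sulfur; no ring) in place of a group of 3 heavy atoms (1 carbon, 1 nitrogen, 1 sulfur; no ring), on a saturated chain carbon, four bonds along the chain from a sulfur. For the measured compounds named here, the one measured step, a 1.5-fold higher number from compound 1 to compound 2 (0.17 log units; within the scatter), is isopropyl in place of propyl on a sulfur, so it concerns another part of the molecule and bears on this change only indirectly. With nothing larger on record, no step beyond the scatter is expected in this assay. The estimated step is a 1.3-fold lower number from compound 2 to compound 3 (0.10 log units; within the scatter). Compound 3 is estimated at 7000 nM, with an expected range from 3500 nM to 14000 nM.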

Compound 3, half-maximal inhibitory concentration: 6780 nM
Compound 3: the middle estimate sits 1.0-fold (0.01 log units) above what was measured; the measured number falls inside the stated range.
By their numbers in this assay, from the lowest: compounds 1, 3 and 2 (each within the scatter of the next).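

In this assay, among the compounds shown here, the first change at this place, a group of 4 heavy atoms in place of a group of 3 heavy atoms on a saturated chain carbon, gives a 1.3-fold lower number from compound 2 to compound 3 (0.11 log units; within the scatter). The earlier step concerned the group on the sulfur, so this result extends the picture to the chain: here too, no step beyond the scatter appears. Nothing available explains this result. As far as these compounds go, whether a longer chain, or an amine on the chain at this place, would give a step beyond the scatter stays open.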